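The compounds below may be only part of what the source reports. "The series", "measured", "known", "first", "only" and "open" are said of these compounds alone.

Compound 1 `O=C(Nc1ccc(Oc2ccc(-c3ncc[nH]3)cc2)cc1)Nc1cccc(C(F)(F)F)c1` gives 30% in a functional assay on A549 cells (Homo sapiens) for inhibition, read by MTT assay and WST assay, with a stated time of 72 h, tested at 10 uM; a lower number here means less inhibition of growth, a higher number more inhibition of growth at the concentration tested.
Compound 2 `O=C(Nc1ccc(Oc2ccc(-c3ncc[nH]3)cc2)cc1)Nc1cc(C(F)(F)F)ccc1Cl` gives 22.3% in this assay.

Among the two numbers shown, compound 2 stands lowest, with compound 1 nearest; the step of a number 7.7 percentage points lower from compound 1 to compound 2 (within the scatter) lies within the scatter, so the two values cannot be ordered with confidence. Compound 3 `O=C(Nc1ccc(Oc2ccc(-c3ncc[nH]3)cc2)cc1)Nc1ccc(F)c(Cl)c1` has not yet been measured in this assay. It differs from compound 2 in one place: 3-chloro-4-fluorophenyl in place of 2-chloro-5-(trifluoromethyl)phenyl on an amide-type nitrogen. Among the compounds with values here, the only measured step, a chloro in place of hydrogen on an aromatic carbon, changed the aryl group on that amide-type nitrogen by a single atom and left the number within the scatter. Within the data shown here, the change to compound 3 exchanges the whole aryl group, so no measured step bears on it directly; the single step available merely suggests that small changes at this position have not moved the number beyond the scatter. No step beyond the scatter in either direction is therefore expected. Compound 3 is expected to give about 25%, with a range from 5% to 50%. The estimated step is a number 2.7 percentage points higher from compound 2 to compound 3 (within the scatter), within the scatter.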

Compound 3, percent growth inhibition at one concentration: 14.6%
The estimate for compound 3 lay 10.4 percentage points above the measured number; the range from low to high includes it.
By their numbers in this assay, from the lowest: compounds 3, 2 and 1 (each within the scatter of the next, the first and the last beyond it).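

Within the data shown here, at the aryl group on the amide-type nitrogen, exchanging the whole group produced the first step beyond the scatter in this assay: with 3-chloro-4-fluorophenyl in place of 3-(trifluoromethyl)phenyl, the result was a number 15.4 percentage points lower from compound 1 to compound 3 (beyond the scatter). With 3-chloro-4-fluorophenyl in place of 2-chloro-5-(trifluoromethyl)phenyl, the result was a number 7.7 percentage points lower from compound 2 to compound 3 (within the scatter), so only the two ends of this short series can be told apart, and the change at this place is shown to matter only in that one comparison. Nothing at hand accounts for the size of either step.

The exchange alters several features of the aryl group at once, so the compounds shown cannot separate the loss of trifluoromethyl from the gain of chloro and fluoro; a plain 3-chlorophenyl or 4-fluorophenyl group would divide that change into smaller parts. From the compounds shown here alone, all three aryl groups carry only halogens or trifluoromethyl, so it remains open how this assay would respond to an amine, a carboxylic acid or a methoxy group on that ring, or to a longer chain in place of the aryl group.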